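This account rests on a few compounds, and the source may have more. Where it says the series, first, only, none or still open, it means among the compounds named here.

Measured compounds in this series:
compound 1 `O=C(CN1CN(c2ccccc2)C2(CCN(C(=O)c3ccc(C4CCCCC4)cc3)CC2)C1=O)NCCO`: 2000 nM
compound 2 `CC(C)(C)OC(=O)NCCCCNC(=O)CN1CN(c2ccccc2)C2(CCN(C(=O)c3ccc(C4CCCCC4)cc3)CC2)C1=O`: 4600 nM
compound 3 `CS(=O)(=O)NCCCNC(=O)CN1CN(c2ccccc2)C2(CCN(C(=O)c3ccc(C4CCCCC4)cc3)CC2)C1=O`: 3800 nM

In an assay on HEK293 cells for displacement of a labelled ligand from NPC1-like intracellular cholesterol transporter 1 (Homo sapiens) (a lower number here means a stronger inhibitor, a higher number a weaker inhibitor), compound 3 gives 3800 nM, the second highest of the three numbers. The step of a 1.2-fold lower number from compound 2 to compound 3 (0.08 log units; within the scatter) and the step of a 1.9-fold higher number from compound 1 to compound 3 (0.28 log units; within the scatter) both lie within the scatter, so compound 3 sits close to both neighbours.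

Compound 4 `CC(C)(C)OC(=O)NCNC(=O)CN1CN(c2ccccc2)C2(CCN(C(=O)c3ccc(C4CCCCC4)cc3)CC2)C1=O` has not been measured. Change from compound 3: (tert-butoxycarbonyl)amino in place of 2-(methanesulfonamido)ethyl on a saturated chain carbon bound to an amide-type nitrogen. Going by the values given here, the step of a 1.2-fold lower number from compound 2 to compound 3 (0.08 log units; within the scatter) swaps the same two end groups, placed further out along the chain, and reads as no change; a 2.3-fold higher number from compound 1 to compound 2 (0.36 log units; beyond the scatter) is the only step beyond the scatter and is modest. Among the compounds with values here, no measured step covers shortening the chain itself. The expected step is therefore a 1.1-fold higher number from compound 3 to compound 4 (0.04 log units; within the scatter), not beyond the scatter. Compound 4 is estimated at 4200 nM, range 1800 nM to 9500 nM.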

Compound 4, half-maximal inhibitory concentration: 1700 nM
Compound 4: the middle estimate sits 2.5-fold (0.39 log units) above what was measured, and the stated range ends above it.
By their numbers in this assay, from the lowest: compounds 4, 1, 3 and 2 (each within the scatter of the next, the first and the last beyond it).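

In this assay the (tert-butoxycarbonyl)amino group on a saturated chain carbon bound to an amide-type nitrogen gives a 2.2-fold lower number from compound 3 to compound 4 (0.35 log units; beyond the scatter) and a 2.7-fold lower number from compound 2 to compound 4 (0.43 log units; beyond the scatter) and thus reads differently from the same end group further out on the chain in compound 2. Against the hydroxymethyl of compound 1 the change gives a 1.2-fold lower number from compound 1 to compound 4 (0.07 log units; within the scatter) and separates nothing. No evidence at hand accounts for these steps.

Open: whether chain length or end group drives these steps. Going by these compounds, also open: how a free amine or a carboxylic acid would read on this carbon.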